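Adding a Second Fluorine to the Benzyl Amide

The source may report more compounds than this note shows. Statements on the series, on what has been measured and on what is new or still open speak of the compounds shown alone.

Compound 1 `COc1ccc2c(=O)c(/C=C/C(=O)NCc3cccc(F)c3)coc2c1`: 28600 nM
Compound 3 `Cc1ccc(CNC(=O)/C=C/c2coc3cc(O)ccc3c2=O)cc1`: 24900 nM
Compound 2 `COc1ccc(NC(=O)/C=C/c2coc3cc(O)ccc3c2=O)cc1`: > 100000 nM, a limit of the assay

These values come from a functional assay (QGY7701 cells, Homo sapiens) for inhibition, read by MTT assay, with a stated time of 48 h; a higher number here means a weaker inhibitor, a lower number a stronger inhibitor. Compound 1 and compound 3 sit within the scatter of each other. Compound 2 reached only a limit, as recorded in the limit of > 100000 nM in this assay, at which 1 of the 3 values shown sits. Within the data shown here, the one measured step, an at least 4.0-fold lower number from compound 2 to compound 3 (0.60 log units; beyond the scatter), swaps an aromatic ring directly on the amide nitrogen for a benzyl group; it does not touch the fluorine pattern.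

Compound 4 `COc1ccc2c(=O)c(/C=C/C(=O)NCc3ccc(F)cc3F)coc2c1` differs from compound 1 by 2,4-difluorophenyl in place of 3-fluorophenyl on a saturated chain carbon bound to an amide-type nitrogen. Among the measured compounds shown here, no measured step bears on that change, so no step beyond the scatter is expected, a 1.0-fold lower number from compound 1 to compound 4 (0.01 log units; within the scatter). Compound 4 is therefore estimated at 28000 nM, with a range from 10000 nM to 80000 nM.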

Compound 4, half-maximal inhibitory concentration: > 100000 nM
Compound 4: only a limit was reported; the forecaster's own chance of this, stated with the estimate: 15%; at least 3.5-fold (0.55 log units) between middle value and limit.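

On the benzyl group of the amide, the fluorine pattern matters: 2,4-difluorobenzyl in place of 3-fluorobenzyl gives an at least 3.4-fold higher number from compound 1 to compound 4 (0.54 log units; beyond the scatter) in this assay. The earlier step changed the whole group on the amide nitrogen, whereas this one shows that a change on the benzyl ring alone can weaken inhibition. Compound 4 gives a limit of the assay rather than a number, and the true size of the step stays unknown: the limit of > 100000 nM in this assay, at which 2 of the 4 values shown sit.

As far as these compounds go, it remains open whether the added fluorine or its new placement matters. A 2-fluorobenzyl or 4-fluorobenzyl group on the core of compound 1 would separate the two.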